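This account rests on a few compounds, and the source may have more. Where it says the series, first, only, none or still open, it means among the compounds named here.

Measured in a functional assay on MDA-MB-231 cells (Homo sapiens) for cytotoxicity, read by MTT assay, with a stated time of 48 h; on this read-out higher numbers stand for weaker inhibition and lower numbers for stronger inhibition:
compound 1 `O=C(/C=C/c1ccc2c(c1)B(O)OC2)c1ccccc1` — 2300 nM
compound 2 `CSc1ccc(C(=O)/C=C/c2ccc3c(c2)B(O)OC3)cc1` — 9800 nM
compound 3 `Nc1ccc(C(=O)/C=C/c2ccc3c(c2)B(O)OC3)cc1` — 25800 nM

Compound 1 gives the lowest number of the three; the steps to compounds 2 and 3 are both beyond the scatter. Compound 4 `COCOc1ccccc1C(=O)/C=C/c1ccc2c(c1)B(O)OC2` differs from compound 1 by methoxymethoxy in place of hydrogen on an aromatic carbon. Going by the values given here, the steps that bear on this are those in which a group enters on an aromatic carbon of the six-membered aromatic ring of carbon only: a 4.3-fold higher number from compound 1 to compound 2 (0.63 log units; beyond the scatter) and an 11-fold higher number from compound 1 to compound 3 (1.05 log units; beyond the scatter). Both substitutions raised the number; a 2.6-fold higher number from compound 2 to compound 3 (0.42 log units; beyond the scatter) shows the size depends on the group. No entering group at the position ortho to a large group has been measured. A modest rise in this assay is therefore expected for compound 4, estimated at a 2.6-fold higher number from compound 1 to compound 4 (0.42 log units; beyond the scatter). The expected value for compound 4 is 6000 nM, range 2300 nM to 16000 nM.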

Compound 4, half-maximal inhibitory concentration: 10200 nM
Beside the measured number, compound 4's estimate is 1.7-fold (0.23 log units) below it; measured number inside the range.
By their numbers in this assay, from the lowest: compound 1; then compounds 2 and 4 (each within the scatter of the next); then compound 3.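

Methoxymethoxy ortho to a large group gives a 4.4-fold higher number from compound 1 to compound 4 (0.65 log units; beyond the scatter) in this assay and is the first entering group measured at this position. A modest rise therefore also occurs here, and compound 1 remains the lowest of the four, with no listed ring substitution going against that rise. Nothing available bears on the reason for this rise.

Going by these compounds, whether the rise belongs to methoxymethoxy or to any group at this position stays open. A hydroxyl, a methoxy or an amine at this position would help separate the two.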